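Swapping Cyclobutyl for Cyclopropylmethyl on the Aromatic Nitrogen

The source may report more compounds than this note shows. Statements on the series, on what has been measured and on what is new or still open speak of the compounds shown alone.

Of the compounds shown here, two built on a shared core have been measured in a physicochemical assay for solubility, measured as kinetic solubility; a lower number here means a less soluble compound, a higher number a more soluble compound. Compound 1 `CC(=O)Nc1cc(-c2ccc(N(C)C(=O)c3c(F)cccc3Cl)c(N3CC4CC4C3)c2)n(C2CCC2)n1` gives 0.5 ug/mL in this assay, the lowest of the two numbers. Compound 2 `CC(=O)Nc1cc(-c2ccc(N(C)C(=O)c3c(Cl)cccc3Cl)c(N3CC4CC4C3)c2)n(C(C)C)n1` gives 0.8 ug/mL in this assay, a value that lies within the scatter of the number for compound 1, so the two cannot be placed in order. Compound 3 `CC(=O)Nc1cc(-c2ccc(N(C)C(=O)c3c(F)cccc3Cl)c(N3CC4CC4C3)c2)n(CC2CC2)n1` has not yet been measured. It differs from compound 1 only in that (cyclopropylmethyl in place of cyclobutyl on an aromatic nitrogen). For the measured compounds named here, no measured pair shows this change directly, and the two known values sit close together at the low end of the scale. The step of a 1.2-fold higher number from compound 1 to compound 3 (0.08 log units; within the scatter) is expected to stay within the scatter, with no clear direction. For compound 3 the estimate is 0.6 ug/mL, with a range from 0.25 ug/mL to 1.5 ug/mL.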

Compound 3, solubility: 10.1 ug/mL
For compound 3 the middle estimate is 17-fold (1.23 log units) below the measured one; the measured number lies above the stated range.
By their numbers in this assay, from the lowest: compounds 1 and 2 (each within the scatter of the next); then compound 3.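

The exchange of cyclobutyl for cyclopropylmethyl on the aromatic nitrogen gives in this assay a 20-fold higher number from compound 1 to compound 3 (1.31 log units; beyond the scatter) and so marks this position as one where a small change in the substituent can matter. The two groups have the same count of heavy atoms, all carbon, and neither carries a net charge, so at this position the way those atoms are joined is enough to move the read-out well beyond the scatter. No measurement shown here accounts for the size of this step.

Compound 2 differs from compound 3 in more than one place, so it cannot show whether the step carries over to the other core substitution. On these data alone, it also remains open how a longer chain, such as n-butyl, or a chain ending in an amine would behave on the same nitrogen.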